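Phenyl in Place of Ethyl on a Ring Amine Nitrogen

The compounds below may be only part of what the source reports. "The series", "measured", "known", "first", "only" and "open" are said of these compounds alone.

Compound 1, `Cc1ccc2oc(SCC(=O)Nc3ccc(-c4nc(-c5ccccc5)c(-c5ccccc5)n4C)cc3)nc2c1`, gives 11% in a functional assay on HT-29 cells (Homo sapiens) for cytotoxicity, read by MTT assay, with a stated time of 24 h, tested at 0.64 ug/mL; a higher number here means a stronger effect of the compound at the concentration tested, a lower number a weaker effect.
Compound 2, `Cn1c(-c2ccc(NC(=O)CSC3=NCCS3)cc2)nc(-c2ccccc2)c1-c1ccccc1`, gives 16.8% in this assay.
Compound 3, `CCN1CCN(CC(=O)Nc2ccc(-c3nc(-c4ccccc4)c(-c4ccccc4)n3C)cc2)CC1`, gives 7.4% in this assay.

All three share the same core and differ only in the group attached to the saturated chain carbon bound to the carbonyl carbon. Compound 3 sits within the scatter of both companions: the steps of a number 3.6 percentage points lower from compound 1 to compound 3 (within the scatter) and a number 9.4 percentage points lower from compound 2 to compound 3 (within the scatter) are small, as is the step of a number 5.8 percentage points higher from compound 1 to compound 2 (within the scatter). None of the three tails, therefore, separates itself from the others in this assay.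

Compound 4, `Cn1c(-c2ccc(NC(=O)CN3CCN(c4ccccc4)CC3)cc2)nc(-c2ccccc2)c1-c1ccccc1`, keeps the tail of compound 3 and changes one piece of it: phenyl in place of ethyl on an amine nitrogen in a ring. Within the data shown here, no measured step touches that amine nitrogen; each measured step swaps the whole tail rather than a substituent on it. Among the measured compounds shown here, the only guidance is that three quite different tails all gave numbers within the scatter of one another, so a change confined to one substituent is not expected to move the read-out beyond the scatter either. Compound 4 is therefore estimated at 9%, between 0% and 25%, which means an expected step of a number 1.6 percentage points higher from compound 3 to compound 4 (within the scatter).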

Compound 4, a percentage reported as activity, at one concentration (the size of the read-out at that concentration, not a potency): 17.3%
Compound 4: middle estimate off by 8.3 percentage points, on the low side, within the range that was stated.
By their numbers in this assay, from the lowest: compounds 3, 1, 2 and 4 (each within the scatter of the next).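

Among these compounds, this is the first step that changes only a substituent on the ring amine nitrogen rather than swapping the whole tail, and in this assay phenyl in place of ethyl gives a number 9.9 percentage points higher from compound 3 to compound 4 (within the scatter). So even this change, from a small open chain to a whole aromatic ring at this nitrogen, does not move the read-out beyond the scatter, and the 4-phenylpiperazin-1-yl tail does not separate itself from the two tails of a different type either, with a number 0.5 percentage points higher from compound 2 to compound 4 (within the scatter) and a number 6.3 percentage points higher from compound 1 to compound 4 (within the scatter). There is no supporting information that could explain these numbers.

As far as these compounds go, it remains open whether another group on the same nitrogen, such as benzyl, acetyl or a bare hydrogen, would give a read-out clearly apart from those of compound 3 and compound 4. Since every number here is the size of the effect at one concentration in one cell line, the four compounds also leave open how their potencies compare, which a full concentration series would show.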